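The source may hold more compounds than are shown below. What is called first, only, known or untested is meant among the compounds shown, and "the series" means these compounds.

Compounds measured so far:
compound 1, `COc1ccc(C2=NNC(c3ccco3)C2)cc1OC`, 45%
compound 2, `COc1ccc(C2CC(c3ccc(OC)c(OC)c3)=NN2)c(OC)c1`, 38%

Both were tested in a functional assay on the whole organism (strain albino) for inhibition, with Rattus norvegicus as the target, read by paw edema, with stated times of 30 min and 1 h, at a dose of 100 mg/kg by the oral route; a lower number here means less inhibition, a higher number more inhibition at the dose given (going by the name of the read-out). There compound 1 gives 45%, and compound 2 gives 38%; the two numbers lie within the usual scatter of each other, so neither can be set apart from the other.

Compound 3, `COc1ccc(C2CC(c3ccc(OC)c(OC)c3)=NN2C(=O)CBr)c(OC)c1`, has not yet been measured. It differs from compound 2 in one place: (bromomethyl)carbonyl in place of hydrogen on an amine nitrogen in a ring. Among the compounds with values here, no measured pair shows what such a change does, so the expectation rests on compound 2 alone. The step of a number 2 percentage points higher from compound 2 to compound 3 (within the scatter) is expected to stay within the scatter, with no clear direction. Compound 3 is therefore estimated at 40%, in a range from 20% to 60%.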

Compound 3, a percentage reported as inhibition, in the whole organism at one dose (the size of the read-out at that dose, not a potency): 53%
Compound 3: the middle estimate sits 13 percentage points below what was measured; low and high end bracket the measured number.
By their numbers in this assay, from the lowest: compounds 2, 1 and 3 (each within the scatter of the next, the first and the last beyond it).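

In this assay, putting (bromomethyl)carbonyl in place of hydrogen on the amine nitrogen in the ring brings a number 15 percentage points higher from compound 2 to compound 3 (beyond the scatter) as a modest change. This nitrogen therefore need not keep its hydrogen, and inhibition at the dose given survives a substituent there and even rises. Nothing available explains this rise.

On these data alone, whether the gain comes from the carbonyl or from the bromine stays open, and an acetyl group on the same nitrogen would separate the two. A longer chain or an amine-bearing acyl group there also remains untested in the compounds shown.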